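Swapping the aryl group on a shared core: cytotoxicity expectations

A few compounds are considered here, and "the series" means these few. Any claim that something is new, unique, unknown or untested is made for them only; others in the source may bear on it.

Compound 1 `COc1nc(-c2ccsc2)ccc1[C@@H](c1ccccc1)[C@@](O)(CCN(C)C)c1cccc2ccccc12` and compound 2 `COc1nc(-c2ccncc2)ccc1[C@@H](c1ccccc1)[C@@](O)(CCN(C)C)c1cccc2ccccc12` share one core and differ only in the aryl group attached to it. In a toxicity assay on Vero cells (Chlorocebus sabaeus) for cytotoxicity (a higher number here means that more compound is tolerated, a lower number that less compound is tolerated), compound 1 gives 24.4 ug/mL. In this assay compound 2 gives > 50 ug/mL, which is a limit of the assay and not a number. Compound 2 therefore stands at the limit of > 50 ug/mL in this assay, at which 1 of the 2 values shown sits. The measured step shows an at least 2.0-fold higher number from compound 1 to compound 2 (0.31 log units; beyond the scatter).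

Compound 3 `COc1nc(-c2ccc(Cl)c(F)c2)ccc1[C@@H](c1ccccc1)[C@@](O)(CCN(C)C)c1cccc2ccccc12` is not yet measured. Compared with compound 2 it carries 4-chloro-3-fluorophenyl in place of pyridin-4-yl on an aromatic carbon. Among the compounds with values here, the only step that bears on this change is an at least 2.0-fold higher number from compound 1 to compound 2 (0.31 log units; beyond the scatter), in which replacing a five-membered heteroaryl group by pyridin-4-yl raised the tolerated concentration at least modestly. Moving away from pyridin-4-yl to a carbon-only ring bearing chloro and fluoro is expected to reverse that, so the step of an at least 3.3-fold lower number from compound 2 to compound 3 (0.52 log units; beyond the scatter) is expected to be a fall. For compound 3 the estimate is 15 ug/mL, with a range from 6 ug/mL to 45 ug/mL.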

Compound 3, half-maximal cytotoxic concentration: > 50 ug/mL
Compound 3 ended at the assay's limit; the forecaster's own chance of this, stated with the estimate: 15%; middle value at least 3.3-fold (0.52 log units) away from the limit.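

At this place on the shared core, next to the ring nitrogen, 4-chloro-3-fluorophenyl in place of thiophen-3-yl also brings an at least 2.0-fold higher number from compound 1 to compound 3 (0.31 log units; beyond the scatter). The higher number seen with pyridin-4-yl therefore does not require a nitrogen in the entering ring, since a ring of carbon only reaches the same limit. The step between compound 2 and compound 3 cannot be read in this assay, as both values are limits of the assay and not numbers: the limit of > 50 ug/mL in this assay, at which 2 of the 3 values shown sit.

The compounds shown leave open how far compound 2 and compound 3 lie past that limit, and so which of them is better tolerated. They also leave open whether plain phenyl, without chlorine or fluorine, or a carboxylic acid on the ring would stay at the limit.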